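The source may hold more compounds than are shown below. What is called first, only, known or untested is meant among the compounds shown, and "the series" means these compounds.

In a functional assay on DU-145 cells (Homo sapiens) for antiproliferative activity, read by WST assay, with a stated time of 3 days (a lower number here means a stronger inhibitor, a higher number a weaker inhibitor), compound 1 `CCCCCCOc1c(-c2cc(OC)c(OC)c(OC)c2)oc2ccccc2c1=O` reaches only a limit, > 50000 nM, and not a true number. Among the measured compounds shown here, compound 2 `CCN(CC)CCCCCOc1c(-c2cc(OC)c(OC)c(OC)c2)oc2ccccc2c1=O` gives 33400 nM, the only actual number available so far. For the measured compounds named here, the one measured step is an at least 1.4-fold lower number from compound 1 to compound 2 (0.17 log units; that floor lies within the scatter), so the data do not separate these two compounds.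

Compound 3 `CCCN(CCC)CCCCCOc1c(-c2cc(OC)c(OC)c(OC)c2)oc2ccccc2c1=O` differs from compound 2 as follows: dipropylamino in place of diethylamino on a saturated chain carbon, five bonds along the chain from an oxygen on an aromatic ring. This keeps the chain and changes only the alkyl groups on its nitrogen. The step of an at least 1.4-fold lower number from compound 1 to compound 2 (0.17 log units; that floor lies within the scatter) is the only one that bears on this change, and it put diethylamino in place of methyl, so it gives no measure of what a change between the two amino groups does. No size of step beyond the scatter is therefore expected in this assay. An expected 1.2-fold lower number from compound 2 to compound 3 (0.09 log units; within the scatter) would stay within the scatter. For compound 3 the estimated value is 27000 nM, with an expected range from 12000 nM to 50000 nM.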

Compound 3, half-maximal inhibitory concentration: 24200 nM
For compound 3 the middle estimate is 1.1-fold (0.05 log units) above the measured one, within the range that was stated.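

Among the compounds shown here, the exchange of diethylamino for dipropylamino is the first measure of a change between two amino groups at this place, on a saturated chain carbon, five bonds along the chain from an oxygen on an aromatic ring. In this assay it gives a 1.4-fold lower number from compound 2 to compound 3 (0.14 log units; within the scatter) and so does not tell the two amines apart. For the compounds shown here, an amine on this chain now also stands clear of the plain alkyl chain, with an at least 2.0-fold lower number from compound 1 to compound 3 (0.31 log units; beyond the scatter) as the first step beyond the scatter, but compound 1 gives a limit and not a number, so that step is only a floor: the limit of > 50000 nM in this assay, at which 1 of the 3 values shown sits.

The compounds shown leave open whether a cyclic amine such as piperidine or morpholine, or a shorter or longer chain carrying the amine, would move the number further. They also leave open how a primary amine or a carboxylic acid at the chain end would compare.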